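Trimming a Ring to a Chain on the Core Nitrogen

A few compounds are considered here, and "the series" means these few. Any claim that something is new, unique, unknown or untested is made for them only; others in the source may bear on it.

Compound 1 `C=CCCCn1c(Cc2cc(OC)c(OC)c(OC)c2)nc2c(N)nc(F)nc21` and compound 2 `COc1cc(Cc2nc3c(N)ncnc3n2CC2CCCCC2)cc(OC)c1OC` share the same core and differ only in the group attached to the aromatic nitrogen. In a functional assay on MCF7 cells (Homo sapiens) for antiproliferative activity (on this read-out lower numbers stand for stronger inhibition and higher numbers for weaker inhibition), compound 1 gives 44700 nM. In this assay compound 2 gives 39800 nM, a number that lies within the usual scatter of that of compound 1, so the two cannot be told apart on this read-out. Compound 3 `CCCCCn1c(Cc2cc(OC)c(OC)c(OC)c2)nc2c(N)ncnc21` has not yet been measured. Its difference from compound 2 is butyl in place of cyclohexyl on a saturated chain carbon bound to an aromatic nitrogen. Among the compounds with values here, no measured pair isolates a change of this kind, so the expectation rests on compound 1 and compound 2 alone: both carry a chain on that nitrogen and both sit in the same range in this assay. The step of a 1.1-fold higher number from compound 2 to compound 3 (0.05 log units; within the scatter) is expected to be small, likely none beyond the scatter. Compound 3 is estimated at 45000 nM, with a range from 15000 nM to 130000 nM.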

Compound 3, half-maximal inhibitory concentration: 61700 nM
Compound 3: middle estimate off by 1.4-fold (0.14 log units), on the low side; the range from low to high includes it.
By their numbers in this assay, from the lowest: compounds 2, 1 and 3 (each within the scatter of the next).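

Replacing cyclohexyl with butyl on a saturated chain carbon bound to an aromatic nitrogen gives, in this assay, a 1.6-fold higher number from compound 2 to compound 3 (0.19 log units; within the scatter). This is the first pair shown that isolates this change, and it indicates that on this read-out an open chain and a ring at this position cannot be told apart. No available evidence accounts for this outcome.

As far as these compounds go, it remains open whether any other group at this position would give a difference beyond the scatter, such as a longer chain like octyl, a benzyl group, or a chain carrying an amine or a carboxylic acid. A single pair also cannot show whether the same change would behave alike on a different core.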